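The source may report more compounds than this note shows. Statements on the series, on what has been measured and on what is new or still open speak of the compounds shown alone.

Measured so far in an ADME assay on L6 cells (Rattus norvegicus) for cytotoxicity, read by resazurin assay, with a stated time of 72 h; a lower number here means a stronger inhibitor, a higher number a weaker inhibitor:
- compound 1 `CC(C)c1ccc(C(=O)NC(=O)c2ccccc2O)cc1`: 19 ug/mL
- compound 2 `O=C(NC(=O)c1ccccc1O)c1ccc([N+](=O)[O-])cc1`: 53 ug/mL

Of these two compounds, compound 2 stands highest at 53 ug/mL, and its nearest neighbour is compound 1 at 19 ug/mL. The next compound to be read is compound 3 `COC(=O)c1ccc(C(=O)NC(=O)c2ccccc2O)cc1`, which carries methoxycarbonyl in place of nitro on an aromatic carbon, para to a large group (methoxycarbonyl in place of nitro on an aromatic carbon).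

For the measured compounds named here, only one measured step bears on this change, and it is an indirect guide: nitro in place of isopropyl at the same place gave a 2.8-fold higher number from compound 1 to compound 2 (0.45 log units; beyond the scatter). Going by the values given here, this modest step is the whole of the evidence, and no measured compound carries methoxycarbonyl. The group entering compound 3 has not been tested against either measured group, so a step larger than the measured one is not expected in this assay. The expected direction is weakly towards a lower number, as compound 2 is the higher of the two measured compounds, and the expected size does not go beyond the scatter. The estimated step is a 1.5-fold lower number from compound 2 to compound 3 (0.18 log units; within the scatter). For compound 3 the estimate is 35 ug/mL, with an expected range from 15 ug/mL to 80 ug/mL.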

Compound 3, half-maximal inhibitory concentration: 42 ug/mL
Compound 3: the middle estimate sits 1.2-fold (0.08 log units) below what was measured; the measured number falls inside the stated range.
By their numbers in this assay, from the lowest: compound 1; then compounds 3 and 2 (each within the scatter of the next).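

In this assay, methoxycarbonyl in place of nitro on an aromatic carbon, para to a large group, gives a 1.3-fold lower number from compound 2 to compound 3 (0.10 log units; within the scatter), so these two groups, which have the same counts of hydrogen-bond donors and acceptors, are not separated at this position. Methoxycarbonyl in place of isopropyl gives a 2.2-fold higher number from compound 1 to compound 3 (0.34 log units; beyond the scatter), in the same direction as a 2.8-fold higher number from compound 1 to compound 2 (0.45 log units; beyond the scatter), so compound 1 now stands apart from two other groups at this position, not from nitro alone, and it has the lowest number of the three compounds. No measurement shown gives a reason for this separation.

From the compounds shown here alone, it remains open whether the separation belongs to isopropyl in particular or would extend to other groups at this position, such as an amine, a carboxylic acid or a longer alkyl chain. Going by these compounds, the shared core is otherwise unchanged across these compounds, so it is also open whether the same separation would hold with a different group elsewhere on the core.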